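Replacing the nitro group of compound 1 with hydrogen

A few compounds are considered here, and "the series" means these few. Any claim that something is new, unique, unknown or untested is made for them only; others in the source may bear on it.

Among the compounds with values here, in a physicochemical assay for solubility (a higher number here means a more soluble compound, a lower number a less soluble compound), compound 1 `O=C(Nc1c(Cl)cc([N+](=O)[O-])cc1Cl)c1cc(Cl)ccc1O` gives 53 ug/mL as the only exact number so far. Compound 2 `CN1CCC(NC(=O)c2cc(Cl)ccc2O)CC1` is reported as a limit, > 40 ug/mL, and gives no exact number. Compound 3 `O=C(Nc1c(Cl)cccc1Cl)c1cc(Cl)ccc1O` keeps the core of compound 1 and carries hydrogen in place of nitro on an aromatic carbon, at the site meta to two chloro groups and para to a large group. Within the data shown here, no measured pair shows this change, so the expectation is a cautious one: no shift in this assay beyond the scatter, with no firm direction. The estimated step of a 1.2-fold lower number from compound 1 to compound 3 (0.07 log units; within the scatter) is expected to stay within that scatter. Compound 3 is expected at 45 ug/mL with an estimated range from 15 ug/mL to 110 ug/mL in this measurement.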

Compound 3, solubility: 21 ug/mL
Compound 3: middle estimate off by 2.1-fold (0.33 log units), on the high side, and the stated range covers the measured number.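

In this assay, within the data shown here, hydrogen in place of nitro on the aromatic carbon meta to two chloro groups gives a 2.5-fold lower number from compound 1 to compound 3 (0.40 log units; beyond the scatter), the first step that can be read for a change in one place. The number at this site therefore moves with the group it carries, though this rests on a single pair and makes no trend. Compound 2 stands only as a limit and not as a number, and it differs from both compounds in more than one place, so it adds nothing to this step: the limit of > 40 ug/mL in this assay, at which 1 of the 3 values shown sits.

The values give no cause for the step. Still open, as far as these compounds go, are how a nitrile, a carboxylic acid or an amine on the same carbon would read in this assay, and whether the same exchange on another core gives a step of similar size.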